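Truncating the ring-nitrogen chain of compound 1 to methyl

The compounds below may be only part of what the source reports. "The series", "measured", "known", "first", "only" and "open" are said of these compounds alone.

The measured set in a functional assay (strain AB) with Danio rerio as the target, read by microscopy, with a stated time of 1 h (on this read-out higher numbers stand for an effect only at larger amounts of compound and lower numbers for an effect already at smaller amounts), is small. Compound 1 `CC(C)(C)OC(=O)CCCN1CCc2c(sc(NC(=O)Nc3ccc(Cl)cc3)c2C(N)=O)C1` gives 560 nM and stands highest of the two numbers, but its nearest neighbour compound 3 `NC(=O)c1c(NC(=O)Nc2ccc(Cl)cc2)sc2c1CCN(CCCNC(=O)CCc1cccnc1)C2` gives 470 nM, and the step of a 1.2-fold lower number from compound 1 to compound 3 (0.08 log units; within the scatter) is within the scatter. Going by the values given here, compound 2 `CCN1CCc2c(sc(N)c2C(N)=O)C1` gives only a limit, > 25000 nM, and carries no urea, so it gives no measured step toward compound 1.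

Compound 4 `CN1CCc2c(sc(NC(=O)Nc3ccc(Cl)cc3)c2C(N)=O)C1` differs from compound 1 as hydrogen in place of 2-(tert-butoxycarbonyl)ethyl on a saturated chain carbon bound to an amine nitrogen in a ring. Among the compounds with values here, the only measured step touching this chain is a 1.2-fold lower number from compound 1 to compound 3 (0.08 log units; within the scatter), which exchanged the group at the far end of the chain without a change beyond the scatter, but the chain itself is not removed in any measured pair, so no step bears directly on the change to compound 4. The expectation is therefore uncertain and leans toward a modest loss, with the step of a 2.7-fold higher number from compound 1 to compound 4 (0.43 log units; beyond the scatter) estimated. Compound 4 is expected to give about 1500 nM, in the range 400 nM to 6000 nM.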

Compound 4, half-maximal effective concentration: 4700 nM
The estimate for compound 4 lay 3.1-fold (0.50 log units) below the measured number, within the range that was stated.
By their numbers in this assay, from the lowest: compounds 3 and 1 (each within the scatter of the next); then compound 4. At a limit, above all of these: compound 2.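

In this assay, the change from 3-(tert-butoxycarbonyl)propyl to methyl gives an 8.4-fold higher number from compound 1 to compound 4 (0.92 log units; beyond the scatter), so this position is sensitive to removal of the chain. By contrast, exchanging only the far end of the chain gives a 1.2-fold lower number from compound 1 to compound 3 (0.08 log units; within the scatter). Among these three compounds, the chain's presence therefore matters more on this read-out than which of the two end groups it carries. Compound 2 is a limit of the assay and differs from these compounds in more than one place, so it adds no step: the limit of > 25000 nM in this assay, at which 1 of the 4 values shown sits.

The compounds shown leave open whether the difference follows chain length alone or needs a substituted chain end. A plain butyl chain, compared with a propyl chain ending in a primary amine or a carboxylic acid, would separate these two readings.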